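A few compounds are considered here, and "the series" means these few. Any claim that something is new, unique, unknown or untested is made for them only; others in the source may bear on it.

Measured compounds:
- compound 1 `c1ccc(Sc2nn3cc(-c4cc5ccccc5o4)nc3s2)cc1`: 1900 nM
- compound 2 `COc1cc(OCc2cccc(CCc3ccccc3)c2)c2cc(-c3cn4nc(OC)sc4n3)oc2c1`: 2.4 nM

In a functional assay on HEK293 cells for antagonist activity at proteinase-activated receptor 4 (Homo sapiens), read by FLIPR and calcium flux, with a stated time of 30 min (on this read-out higher numbers stand for weaker inhibition and lower numbers for stronger inhibition), compound 1 gives 1900 nM, the higher of the two numbers shown. Compound 2 gives 2.4 nM in this assay, a far lower number, but compound 2 differs from compound 1 in several places at once, so its value alone does not tell how any single part contributes. Compound 3 `c1ccc2oc(-c3cn4nc(C5CC5)sc4n3)cc2c1` is not yet measured. It differs from compound 1 in one place: cyclopropyl in place of phenylsulfanyl on an aromatic carbon. Going by the values given here, there is no measured pair that isolates this exchange, so the direction of the step is uncertain. Given the value of compound 1 1900 nM in this assay, a modest change in either direction is expected, most likely toward a somewhat lower number, though a step within the scatter would not surprise. Compound 3 is therefore expected to come in at 1000 nM, within 200 nM to 5000 nM, a step of a 1.9-fold lower number from compound 1 to compound 3 (0.28 log units; within the scatter).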

Compound 3, half-maximal inhibitory concentration: 530 nM
Compound 3: the middle estimate sits 1.9-fold (0.28 log units) above what was measured; the measured number falls inside the stated range.
By their numbers in this assay, from the lowest: compound 2; then compound 3; then compound 1.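

In this assay, cyclopropyl in place of phenylsulfanyl on this aromatic carbon of the five-membered ring gives a 3.6-fold lower number from compound 1 to compound 3 (0.55 log units; beyond the scatter), a modest step but one beyond the usual scatter, and it runs toward stronger inhibition. This shows that the phenylsulfanyl group, with its six-membered aromatic ring and its sulfur, is not required at this position, since the much smaller cyclopropyl, with no hydrogen-bond acceptor counted, does better on this read-out. Nothing at hand explains why the exchange has this effect.

A single exchange cannot show whether the gain belongs to cyclopropyl itself or would also come with a primary amine, a morpholine or a longer alkyl chain at this carbon. From the compounds shown here alone, what the methoxy group of compound 2 contributes here also stays open, as that compound differs from the others in several places at once.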